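Naphthyloxyacetyl hydrazones: methyl to chloro on the aryl ring

The source may report more compounds than this note shows. Statements on the series, on what has been measured and on what is new or still open speak of the compounds shown alone.

Going by the values given here, compound 2 `Cc1ccc(/C=N/NC(=O)COc2cccc3ccccc23)cc1` gives 83.9 ug/mL in an ADME assay on MT4 cells (Homo sapiens) for cytotoxicity, read by MTT assay, with a stated time of 4 days (on this read-out higher numbers stand for lower toxicity in this test and lower numbers for higher toxicity in this test), the higher of the two numbers measured so far. Among the compounds with values here, compound 1 `O=C(COc1cccc2ccccc12)N/N=C/c1ccc(O)cc1` gives 26.5 ug/mL in this assay, and the one step that joins the two, a 3.2-fold higher number from compound 1 to compound 2 (0.50 log units; beyond the scatter), comes from methyl in place of hydroxy on an aromatic carbon.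

Compound 3 `O=C(COc1cccc2ccccc12)N/N=C/c1ccc(Cl)cc1` differs from compound 2 by chloro in place of methyl on an aromatic carbon. Within the data shown here, no measured step covers the exchange of methyl for chloro, so the series offers no direct guide. Among the measured compounds shown here, the single known step concerns hydroxy leaving and methyl entering, and it sets the scale of what one aromatic substituent has done here; a second exchange at the same place is expected to move the number by less than that, likely within the scatter, in either direction.

For compound 3 the expected step is a 1.2-fold lower number from compound 2 to compound 3 (0.08 log units; within the scatter) in this assay, with no direction firmly favoured. The estimate for compound 3 in this assay is therefore 70 ug/mL, within 30 ug/mL to 160 ug/mL.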

Compound 3, half-maximal cytotoxic concentration: 87.6 ug/mL
Compound 3: the middle estimate sits 1.3-fold (0.10 log units) below what was measured, and the stated range covers the measured number.
By their numbers in this assay, from the lowest: compound 1; then compounds 2 and 3 (each within the scatter of the next).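

Chloro in place of methyl on an aromatic carbon, para to a large group, gives a 1.0-fold higher number from compound 2 to compound 3 (0.02 log units; within the scatter) in this assay, so the two groups cannot be told apart at this place in this test. Chloro in place of hydroxy gives a 3.3-fold higher number from compound 1 to compound 3 (0.52 log units; beyond the scatter), a step of about the size of a 3.2-fold higher number from compound 1 to compound 2 (0.50 log units; beyond the scatter), so two different groups now stand apart from hydroxy, and among these three compounds only compound 1 lies on the side of higher toxicity in this test. No available evidence bears on what sets these numbers.

Three groups at one place cannot show whether hydroxy is unusual in giving the lower number or whether other groups there, such as an amine, a carboxylic acid or a methoxy group, would fall with it or with methyl and chloro. Going by these compounds, it also remains open whether the match between methyl and chloro holds with a longer chain in place of methyl, or with the same exchange made on a different part of the shared core.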